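This account rests on a few compounds, and the source may have more. Where it says the series, first, only, none or still open, it means among the compounds named here.

The study concerns nucleoside-like compounds carrying a sulfur-linked aryl group, tested in an assay on isolated protein for binding affinity to Equilibrative nucleoside transporter 1 (Homo sapiens); on this read-out lower numbers stand for stronger inhibition and higher numbers for weaker inhibition. Compound 1 `Nc1nc(SCc2ccc(F)cc2)c2ncn([C@@H]3O[C@H](CO)[C@@H](O)[C@H]3O)c2n1` bears a 4-fluorophenyl group on its sulfur and an amino group on the shared core; in this assay compound 1 gives 1150 nM. Compound 2 `OC[C@H]1O[C@@H](n2cnc3c(CSc4ccccc4Br)ncnc32)[C@H](O)[C@@H]1O` bears a 2-bromophenyl group on the sulfur and has no amino group; in this assay compound 2 gives 2400 nM. Of the two numbers measured, that of compound 2 is the higher, and its gap to compound 1 lies beyond the usual scatter, so compound 2 is the weaker inhibitor of the pair. Compound 1 and compound 2 differ in more than one place. Their two values say nothing about any single change.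

Compound 3 `OC[C@H]1O[C@@H](n2cnc3c(CSc4ccc(Br)cc4)ncnc32)[C@H](O)[C@@H]1O` has not yet been measured. It differs from compound 2 in one place: 4-bromophenyl in place of 2-bromophenyl on a sulfur. Among the compounds with values here, no step between measured compounds that differ in a single place is available to guide an expectation. The author therefore expects a modest step, leaning toward a somewhat lower number, estimated as a 1.6-fold lower number from compound 2 to compound 3 (0.20 log units; within the scatter). Compound 3 is expected to give 1500 nM, within a range from 500 nM to 4500 nM.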

Compound 3, half-maximal inhibitory concentration: 178 nM
Compound 3: middle estimate off by 8.4-fold (0.93 log units), on the high side; the whole stated range lies above it.
By their numbers in this assay, from the lowest: compound 3; then compound 1; then compound 2.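

Exchanging 2-bromophenyl for 4-bromophenyl on a sulfur whose other neighbour is a saturated chain carbon gives a 13-fold lower number from compound 2 to compound 3 (1.13 log units; beyond the scatter) in this assay. Within the data shown here, this is the first change that can be read on its own, since compound 1 and compound 2 differ in more than one place. The two groups have the same heavy atoms, the same aromatic ring and the same counts of hydrogen-bond donors and acceptors, and yet the value moves by a large step, showing that at this position the inhibition depends strongly on where the bromine sits on the phenyl group, although nothing measured here accounts for the size of that step.

On these data alone, whether a chlorine or a methoxy group in place of the bromine of the 4-bromophenyl group would keep the lower number remains open. As far as these compounds go, it is also open whether the same exchange would give a step of similar size on a core carrying the amino group of compound 1.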